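The compounds below may be only part of what the source reports. "The series", "measured", "known", "first", "only" and "open" are said of these compounds alone.

Four compounds share one outer portion and differ in their central core and in a single substituent. Compound 1 `COc1ccccc1OCCNc1cnn(Cc2ccc(OC)c(OCC3CC3)c2)c(=O)c1Cl` and compound 2 `COc1ccccc1OCCNc1ccc(=O)n(Cc2ccc(OC)c(OCC3CC3)c2)n1` carry different cores; the difference between the two cores is not broken down here. In a functional assay on SH-SY5Y cells (Homo sapiens) for antiproliferative activity, read by MTT assay, with a stated time of 48 h (a lower number here means a stronger inhibitor of growth, a higher number a weaker inhibitor of growth), compound 1 gives 37900 nM, and compound 2 gives 10500 nM. Compound 3 `COc1ccccc1OCCNc1ccc(=O)n(Cc2ccc(OC(F)F)c(OCC3CC3)c2)n1` is compound 2 with one alteration, (difluoromethyl in place of methyl on an oxygen on an aromatic ring), and in this assay compound 3 gives 6300 nM; the resulting step is a 1.7-fold lower number from compound 2 to compound 3 (0.22 log units; within the scatter). Compound 4 `COc1ccccc1OCCNc1cnn(Cc2ccc(OC(F)F)c(OCC3CC3)c2)c(=O)c1Cl` has not yet been measured; it stands to compound 1 as compound 3 stands to compound 2, through (difluoromethyl in place of methyl on an oxygen on an aromatic ring), the same change at the same kind of place. Among the compounds with values here, because the one measured example of this change, a 1.7-fold lower number from compound 2 to compound 3 (0.22 log units; within the scatter), moved the number only slightly, a similarly modest shift is expected for compound 4, namely a 1.7-fold lower number from compound 1 to compound 4 (0.24 log units; within the scatter). Compound 4 is therefore expected to give about 22000 nM in this assay, most likely falling between 9000 nM and 50000 nM.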

Compound 4, concentration for 50% growth inhibition: > 100000 nM
Compound 4 ended at the assay's limit (the forecaster's own chance of this, stated with the estimate: 10%); middle value at least 4.5-fold (0.65 log units) from the limit.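

On the core of compound 1, replacing methoxy with difluoromethoxy brings an at least 2.6-fold higher number from compound 1 to compound 4 (0.42 log units; beyond the scatter), so this change did not behave the same way on the two cores in this assay: the same change on two cores in this assay, a 1.7-fold lower number (0.22 log units; within the scatter) from compound 2 to compound 3 and an at least 2.6-fold higher number (0.42 log units; beyond the scatter) from compound 1 to compound 4, at least 4.3-fold (0.64 log units) apart, beyond the scatter of two such steps

Compound 4 gives > 100000 nM, which is a limit of the assay and not a number, so only the smallest possible size of this step is known. With a single pair on each core, the result shows that the step seen on one core did not predict the step on the other, but it does not show why the two cores differ or how the change would behave on any further core.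

The compounds shown leave open whether a different group on the same oxygen, such as ethyl or trifluoromethyl, would also separate the two cores. They also leave open which part of the difference between the cores matters, as the cores are compared here only as wholes.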